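Pyrazoline series: benzoyl to propanoyl at the ring nitrogen

This account rests on a few compounds, and the source may have more. Where it says the series, first, only, none or still open, it means among the compounds named here.

Measured compounds:
- compound 1, `CCC(=O)N1N=C(C)CC1c1cc(Br)cc(Br)c1O`, 28600 nM
- compound 2, `CC1=NN(C(=O)CN2CCC(c3ccccc3)CC2)C(c2ccccc2O)C1`, 20400 nM
- compound 3, `O=C(c1ccccc1)N1N=C(c2cc3ccccc3oc2=O)CC1c1ccccc1`, 5870 nM

All three were read in a functional assay on PC-3 cells (Homo sapiens) for cytotoxicity, read by MTT assay, with a stated time of 48 h; a lower number here means a stronger inhibitor, a higher number a weaker inhibitor. Compound 3 gives the lowest number of the three in this assay, and both other compounds lie beyond the scatter from it: compound 2 is higher, compound 1 higher still. Compound 3 is therefore the strongest inhibitor among the measured compounds. Going by the values given here, no pair among them differs in one place only, so no single step can be drawn between them; compound 1 and compound 2 show only that their numbers are weaker than that of compound 3.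

Compound 4, `CCC(=O)N1N=C(c2cc3ccccc3oc2=O)CC1c1ccccc1`, has not yet been measured in this assay. Against compound 3 the change is ethyl in place of phenyl on a carbonyl carbon. Among the compounds with values here, no measured step covers this change. Compound 1 also carries a propanoyl group but differs from compound 4 in other places too, so its value tells nothing definite about this step. Within the data shown here, with no step to rest on, a small loss is expected: from compound 3 to compound 4 the step of a 1.7-fold higher number from compound 3 to compound 4 (0.23 log units; within the scatter) is estimated, which is within or close to the scatter. Compound 4 is expected to give 10000 nM in this assay, with a range from 4000 nM to 30000 nM.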

Compound 4, half-maximal inhibitory concentration: 4370 nM
Compound 4: the middle estimate sits 2.3-fold (0.36 log units) above what was measured, within the range that was stated.
By their numbers in this assay, from the lowest: compounds 4 and 3 (each within the scatter of the next); then compounds 2 and 1 (each within the scatter of the next).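

In this assay, ethyl in place of phenyl on a carbonyl carbon gives a 1.3-fold lower number from compound 3 to compound 4 (0.13 log units; within the scatter), so the two groups cannot be told apart at this position. Going by these compounds alone, on this core, a six-membered aromatic ring of carbon only, with 6 heavy atoms, and an ethyl with 2 heavy atoms give values within the scatter of each other, which means the ring is not needed to hold the number at this level; the earlier compounds could not show this, as compounds 1 and 2 each differ from compound 3 in more than one place. Nothing at hand bears on why the two groups read alike.

This single step gives only two points at the position, and it leaves open whether a longer chain such as hexanoyl, a cyclohexyl on the carbonyl carbon, or a chain ending in an amine or a carboxylic acid would stay within the scatter or move the number beyond it. As far as these compounds go, whether ethyl and phenyl also read alike on the cores of compound 1 and compound 2 remains open as well.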